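Cytotoxicity notes on allyloxy chalcone analogues with varied aryl tails

A few compounds are considered here, and "the series" means these few. Any claim that something is new, unique, unknown or untested is made for them only; others in the source may bear on it.

Compound 1, `C=CCOc1cc(OC)c(C(=O)/C=C/C=C/c2ccccc2)c(OCC=C)c1`: in an ADME assay on Vero cells (Chlorocebus sabaeus) for cytotoxicity, read by MTT assay (a lower number here means a stronger inhibitor, a higher number a weaker inhibitor), compound 1 gives "not determined" (no result reported).
Compound 2, `C=CCOc1cc(OC)c(C(=O)/C=C/c2ccc(C)cc2)c(OCC=C)c1`: in this assay compound 2 gives 211000 nM.
Compound 3, `C=CCOc1cc(OC)c(C(=O)/C=C/c2ccccc2F)c(OCC=C)c1`: in this assay compound 3 gives 16300 nM.
Compound 4, `C=CCOc1cc(OC)c(C(=O)/C=C/c2ccncc2)c(OCC=C)c1`: not yet measured in this assay.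

Compound 1 stands nowhere on the numbers shown; this assay reported no result for it. Compound 4 differs from it by pyridin-4-yl in place of 2-phenylethenyl on a double-bonded chain carbon bound to a double-bonded chain carbon. Within the data shown here, the only measured step, a 13-fold lower number from compound 2 to compound 3 (1.11 log units; beyond the scatter), is a swap of one aryl group at the same place and is large, so a swap of that kind can move this assay well beyond the scatter, though its direction for compound 4 cannot be read from one step. Compound 4 is estimated at 60000 nM, with an expected range from 12000 nM to 250000 nM.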

Compound 4, half-maximal inhibitory concentration: 2800 nM
The estimate for compound 4 lay 21-fold (1.33 log units) above the measured number, outside the stated range (below it).
By their numbers in this assay, from the lowest: compound 4; then compound 3; then compound 2.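

At this place, on a double-bonded chain carbon bound to a double-bonded chain carbon, this assay gives a 5.8-fold lower number from compound 3 to compound 4 (0.77 log units; beyond the scatter) and a 75-fold lower number from compound 2 to compound 4 (1.88 log units; beyond the scatter) when pyridin-4-yl enters. Among the measured compounds, an aromatic ring with a hetero atom thus gives a lower number than either carbon-only aryl group, and the earlier step between 4-methylphenyl and 2-fluorophenyl did not reach this range. No measurement shown accounts for the shift.

Going by these compounds, whether an aliphatic amine or a carboxylic acid at this place would lower the number as well remains open. With no number for compound 1, the change from 2-phenylethenyl cannot be read.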